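Swapping the aryl group on the ether side chain

This account rests on a few compounds, and the source may have more. Where it says the series, first, only, none or still open, it means among the compounds named here.

Measured so far:
- compound 1 `C[C@@H](Oc1cc2oc(=O)n(CCC(=O)O)c2cc1Cl)c1ccc(F)cn1`: 2.51 nM
- compound 2 `CC(C)Cc1cc2oc(=O)n(CCC(=O)O)c2cc1Cl`: 12.6 nM
- compound 3 `COc1cc2oc(=O)n(CCC(=O)O)c2cc1Cl`: 12.6 nM

The read-out throughout is an assay for inhibition of kynurenine 3-monooxygenase (Homo sapiens), read by mass spectrometry, with a stated time of 1 h; a higher number here means a weaker inhibitor, a lower number a stronger inhibitor. Compound 1 has the lowest of the three numbers in this assay, and its gap to compound 2 and to compound 3 lies beyond the scatter, so among these compounds it is the strongest inhibitor. Compound 2 and compound 3 differ only in the group on the aromatic carbon, and the step from one to the other shows no change at the digits printed from compound 2 to compound 3 (within the scatter).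

Compound 4 `Cc1ccnc([C@@H](C)Oc2cc3oc(=O)n(CCC(=O)O)c3cc2Cl)c1` has not yet been measured. It differs from compound 1 as follows: 4-methylpyridin-2-yl in place of 5-fluoropyridin-2-yl on a saturated chain carbon bound to an oxygen on an aromatic ring and a saturated chain carbon. Within the data shown here, no measured pair changes this part of the molecule, so there is no step that bears directly on it; the only measured step concerns a different position and shows no change beyond the scatter. The shared core, the acid-bearing chain and the ether link are all kept. The expectation is therefore that compound 4 stays close to compound 1, with a step of a 1.4-fold higher number from compound 1 to compound 4 (0.14 log units; within the scatter) that may be no change beyond the scatter. Compound 4 is estimated at 3.5 nM, within a range of 1.2 nM to 10 nM.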

Compound 4, half-maximal inhibitory concentration: 3.98 nM
Beside the measured number, compound 4's estimate is 1.1-fold (0.06 log units) below it; low and high end bracket the measured number.
By their numbers in this assay, from the lowest: compounds 1 and 4 (each within the scatter of the next); then compounds 2 and 3 (each within the scatter of the next).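

In this assay, among these compounds, 4-methylpyridin-2-yl in place of 5-fluoropyridin-2-yl gives a 1.6-fold higher number from compound 1 to compound 4 (0.20 log units; within the scatter), and this is the first measured pair that changes this part of the molecule. The two groups have the same count of heavy atoms and the same kind of six-membered aromatic ring with one hetero atom, and they differ in that one carries a fluorine and the other a methyl group at a different ring position, yet this single exchange leaves the two compounds indistinguishable in this measurement. Nothing available here gives a reason for this result.

Among the compounds shown here, this is only one pair, so it cannot show how much variety this saturated chain carbon will accept, and how a plain phenyl ring or a group bearing an amine would read at this place remains open. Whether the fluorine or the methyl group contributes anything at all is also unresolved, since telling that would take a comparison with an unsubstituted pyridin-2-yl group.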